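Hydroxylated Secondary Amine in Place of Diethylamino

The compounds below may be only part of what the source reports. "The series", "measured", "known", "first", "only" and "open" are said of these compounds alone.

Within the data shown here, compound 2 `CCN(CC)c1ccc(NC(=O)c2cc(Cl)ccc2O)c(Cl)c1` gives 55500 nM in an ADME assay on A549 cells (Homo sapiens) for cytotoxicity, read by resazurin assay, with a stated time of 48 h (on this read-out lower numbers stand for higher toxicity in this test and higher numbers for lower toxicity in this test), the highest of the three numbers measured so far. Compound 1 `CCCCCCC(C)Nc1ccc(NC(=O)c2cc(Cl)ccc2O)c(Cl)c1` gives 23500 nM in this assay, and compound 3 `O=C(Nc1ccc(NCc2cc(Cl)cc(Cl)c2)cc1Cl)c1cc(Cl)ccc1O` gives 13300 nM. The step of a 2.4-fold higher number from compound 1 to compound 2 (0.37 log units; beyond the scatter) is the only one that touches the diethylamino group of compound 2; the step of a 1.8-fold lower number from compound 1 to compound 3 (0.25 log units; within the scatter) swaps one substituent on the ring nitrogen for another and stays within the scatter.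

Compound 4 `CC(CCO)Nc1ccc(NC(=O)c2cc(Cl)ccc2O)c(Cl)c1` has not yet been measured in this assay. It differs from compound 2 as follows: (3-hydroxy-1-methylpropyl)amino in place of diethylamino on an aromatic carbon. Neither measured step is a direct precedent, but compound 1 and compound 3, both carrying a secondary amino group as compound 4 does, sit below compound 2 in this assay. The expected step is therefore a 1.6-fold lower number from compound 2 to compound 4 (0.20 log units; within the scatter), modest and toward a lower number. Compound 4 is estimated at 35000 nM, with a range from 15000 nM to 80000 nM.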

Compound 4, half-maximal cytotoxic concentration: 200000 nM
Compound 4: middle estimate off by 5.7-fold (0.76 log units), on the low side; measured number above the stated range.
By their numbers in this assay, from the lowest: compounds 3 and 1 (each within the scatter of the next); then compound 2; then compound 4.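

In this assay a secondary amino group at this position does not by itself go with a lower number: compound 1 and compound 3 lie below compound 2, while the (3-hydroxy-1-methylpropyl)amino group of compound 4 goes the other way (a 3.6-fold higher number from compound 2 to compound 4 (0.56 log units; beyond the scatter)). Among the three secondary amines, the hydroxy-bearing chain stands well apart, both from the 1-methylheptyl group (an 8.5-fold higher number from compound 1 to compound 4 (0.93 log units; beyond the scatter)) and from the 3,5-dichlorobenzyl group (a 15-fold higher number from compound 3 to compound 4 (1.18 log units; beyond the scatter)). No measurement shown here explains these steps.

Going by these compounds, the step from compound 1 to compound 4 both shortens the chain and adds the hydroxy, so the share of each remains open. A methoxy in place of that hydroxy, or a plain butan-2-yl group on the nitrogen, would bear on this question.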